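This account rests on a few compounds, and the source may have more. Where it says the series, first, only, none or still open, it means among the compounds named here.

Compound 1, `COc1ccc(N(C)c2ncnc3c2ncn3Cc2cc(OC)cc(OC)c2)cc1`, gives > 100000 nM; compound 2, `COc1ccc(N(C)c2ncnc3c2ncn3Cc2cc(OC)c(OC)c(OC)c2)cc1`, gives 260 nM; compound 3, `COc1ccc(Cn2cnc3c(Cl)ncnc32)cc1`, gives > 50000 nM.

These three compounds were tested in a functional assay on SH-SY5Y cells (Homo sapiens) for antiproliferative activity, read by MTT assay, with a stated time of 48 h; on this read-out higher numbers stand for weaker inhibition of growth and lower numbers for stronger inhibition of growth. For compound 1 the reported value is a limit of the assay and not a number, namely (the limit of > 100000 nM in this assay, at which 1 of the 3 values shown sits). Compound 2 is a numbered result in this assay. The two differ by methoxy in place of hydrogen on an aromatic carbon, and this single change makes an at least 380-fold lower number from compound 1 to compound 2 (2.58 log units; beyond the scatter).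

For compound 3 the value in this assay is again a limit and not a number, (the limit of > 50000 nM in this assay, at which 1 of the 3 values shown sits). How the core of compound 3 differs from the core of compound 1 is not broken down here.

Compound 4, `COc1ccc(Cn2cnc3c(Cl)ncnc32)cc1OC`, has not yet been measured. It differs from compound 3 by methoxy in place of hydrogen on an aromatic carbon. Among the measured compounds shown here, this is the same kind of change as the one from compound 1 to compound 2, but not the same: in compound 2 the entering methoxy sits ortho to two methoxy groups and para to a large group, whereas in compound 4 it sits ortho to a methoxy group and meta to a large group, and the cores are different. The account expects the step from compound 3 to compound 4 to be an at least 1.2-fold lower number from compound 3 to compound 4 (0.09 log units; that floor lies within the scatter), which rests on the two compounds sharing the core of compound 3, whose value > 50000 nM is only a limit, and on the large step from compound 1 to compound 2 having arisen at a differently surrounded place. Compound 4 is therefore estimated at 40000 nM, between 5000 nM and 150000 nM.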

Compound 4, concentration for 50% growth inhibition: > 100000 nM
Compound 4 gave a limit, no number (the forecaster's own chance of this, stated with the estimate: 55%); at least 2.5-fold (0.39 log units) between middle value and limit.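

In this assay compound 4 gives > 100000 nM, which is a limit and not a number. Among the compounds shown here, compound 3 gives > 50000 nM, which is also a limit, so no step between these two compounds can be read. The compounds shown leave open whether methoxy in place of hydrogen on an aromatic carbon changes growth inhibition at all on the core of compound 3.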